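Isopentyloxy for pyrrolidin-1-yl in a TRPV1 antagonist series

The source may report more compounds than this note shows. Statements on the series, on what has been measured and on what is new or still open speak of the compounds shown alone.

Measured compounds:
compound 1 `CC(C(=O)NCc1ccc(C(F)(F)F)cc1N1CCCC1)c1ccc(NS(C)(=O)=O)c(F)c1`: 2.3 nM
compound 2 `CC(C(=O)NCc1ccc(C(F)(F)F)cc1N1CCN(C2CCCCC2)CC1)c1ccc(NS(C)(=O)=O)c(F)c1`: 13.8 nM
compound 3 `CCCCCCOc1cc(C(C)(F)F)ccc1CNC(=O)C(C)c1ccc(NS(C)(=O)=O)c(F)c1`: 0.8 nM

The series is followed in an assay on CHO cells for antagonist activity at transient receptor potential cation channel subfamily V member 1 (Homo sapiens), read by FLIPR; a higher number here means a weaker inhibitor, a lower number a stronger inhibitor. Compound 1 stands second highest of the three numbers; its nearest neighbour is compound 3, and compound 2 lies furthest from it. Going by the values given here, the only single-point step available is a 6.0-fold higher number from compound 1 to compound 2 (0.78 log units; beyond the scatter), which shows that a larger ring-bearing group in that place weakens binding. Compound 4 `CC(C)CCOc1cc(C(F)(F)F)ccc1CNC(=O)C(C)c1ccc(NS(C)(=O)=O)c(F)c1` differs from compound 1 as follows: isopentyloxy in place of pyrrolidin-1-yl on an aromatic carbon. Compound 3 also differs from compound 1 in this place, but in a second place as well, so only its two values can be set beside each other, and they show compound 3 the stronger inhibitor. Among the compounds with values here, the replacement in compound 4 is a chain, not a ring, and no measured step tells how such a chain behaves here. Compound 4 is therefore expected to land close to compound 1, with a 1.5-fold lower number from compound 1 to compound 4 (0.19 log units; within the scatter) as the estimated step, leaning slightly toward compound 3. The expected value for compound 4 is 1.5 nM, within 0.5 nM to 4.5 nM.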

Compound 4, inhibition constant: 0.5 nM
Compound 4: the middle estimate sits 3.0-fold (0.48 log units) above what was measured; measured number inside the range.
By their numbers in this assay, from the lowest: compounds 4 and 3 (each within the scatter of the next); then compound 1; then compound 2.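

In this assay, going by these compounds alone, isopentyloxy gives the first single-place change at this position that lowers the number (a 4.6-fold lower number from compound 1 to compound 4 (0.66 log units; beyond the scatter)), whereas the only earlier step here raised it. The larger step (a 28-fold lower number from compound 2 to compound 4 (1.44 log units; beyond the scatter)) sets the same chain far from 4-cyclohexylpiperazin-1-yl, so among compounds 1, 2 and 4, the ring-free, oxygen-linked group gives the lowest number on this aromatic carbon. Nothing available bears on why the number falls with this change.

Still open, on these data alone, is whether the oxygen or the chain carries the change: a carbon-linked isopentyl group and a shorter alkoxy such as methoxy would separate the two. Also open, as far as these compounds go, is whether an open-chain amine such as diethylamino in this place would track isopentyloxy or pyrrolidin-1-yl.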